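A few compounds are considered here, and "the series" means these few. Any claim that something is new, unique, unknown or untested is made for them only; others in the source may bear on it.

Measured compounds:
- compound 1, `C/C(=C\CC/C(C)=C/CC[C@@H]1[C@@]2(C)CCC(=O)C(C)(C)[C@H]2CC[C@@]1(C)O)CC/C=C(\C)C(=O)OCc1cn(-c2cccc(Cl)c2)nn1`: 111000 nM
- compound 2, `C/C(=C\CC/C(C)=C/CC[C@@H]1[C@@]2(C)CCC(=O)C(C)(C)[C@H]2CC[C@@]1(C)O)CC/C=C(\C)C(=O)O`: 96700 nM

In a functional assay on SiHa cells (Homo sapiens) for antiproliferative activity, read by MTT assay, with a stated time of 48 h (on this read-out higher numbers stand for weaker inhibition and lower numbers for stronger inhibition), compound 1 gives 111000 nM, the higher of the two numbers; compound 2 gives 96700 nM, and the gap between the two is within the scatter, so no order is read from it.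

Compound 3, `C/C(=C\CC/C(C)=C/CC[C@@H]1[C@@]2(C)CCC(=O)C(C)(C)[C@H]2CC[C@@]1(C)O)CC/C=C(\C)C(=O)OCc1cn(-c2cccc(C)c2)nn1`, differs from compound 1 by methyl in place of chloro on an aromatic carbon. Among the measured compounds shown here, no step between measured compounds covers this change. The two measured values sit close together and nothing in them points either way, so the expected step in this assay is small, within the scatter, with no set direction. Compound 3 is estimated at 110000 nM, range 50000 nM to 250000 nM, the expected step being a 1.0-fold lower number from compound 1 to compound 3 (0.00 log units; within the scatter).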

Compound 3, half-maximal inhibitory concentration: > 150000 nM
Compound 3: no number, only a limit; the forecaster's own chance of this, stated with the estimate: 20%; middle value at least 1.3-fold (0.13 log units) from the limit.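

In this assay compound 3, carrying 3-methylphenyl in place of 3-chlorophenyl, gives > 150000 nM, which is a limit of the assay and not a number. Methyl in place of chloro reads as an at least 1.3-fold higher number from compound 1 to compound 3 (0.13 log units; that floor lies within the scatter); the true size of the step stays unread, and nothing shows stronger inhibition with methyl at this place. Only a limit bounds this step: the limit of > 150000 nM in this assay, at which 1 of the 3 values shown sits.

As far as these compounds go, how far the value of compound 3 lies past that limit stays open. Also open, from the compounds shown here alone, is whether an amine, a methoxy group or a nitrile on the same aromatic carbon would give a step beyond the scatter.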